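Pyrimidine for pyridine on a shared aminothienopyrimidine scaffold

The source may report more compounds than this note shows. Statements on the series, on what has been measured and on what is new or still open speak of the compounds shown alone.

Three compounds share one core and differ only in the aryl group on it. In a functional assay on CHO-K1 cells for antagonist activity at adenosine receptor A1 (Homo sapiens), read by a beta-galactosidase reporter and cAMP accumulation, with stated times of 15 min and 6 h (on this read-out lower numbers stand for stronger inhibition and higher numbers for weaker inhibition), compound 1 `N#Cc1ccc(-c2nc(N)c3cc(Cc4ccccc4)sc3n2)o1` gives 3160 nM, compound 2 `Nc1nc(-c2ccc(C(F)F)o2)nc2sc(Cc3ccccc3)cc12` gives 3000 nM, and compound 3 `Nc1nc(-c2cccnc2)nc2sc(Cc3ccccc3)cc12` gives 1420 nM, the lowest of the three. The steps of a 2.2-fold lower number from compound 1 to compound 3 (0.35 log units; beyond the scatter) and a 2.1-fold lower number from compound 2 to compound 3 (0.32 log units; beyond the scatter) are both modest and both exchange a furan for a six-membered ring. Compound 4 `Nc1nc(-c2ncccn2)nc2sc(Cc3ccccc3)cc12` carries pyrimidin-2-yl in place of pyridin-3-yl on an aromatic carbon. Within the data shown here, no measured step swaps one six-membered ring for another, so no direct precedent exists. With pyridin-3-yl already the best of the three, the exchange is expected to produce a 1.3-fold higher number from compound 3 to compound 4 (0.10 log units; within the scatter), a step not clearly beyond the scatter. Compound 4 is therefore estimated at 1800 nM, with a range of 700 nM to 4500 nM.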

Compound 4, inhibition constant: 618 nM
For compound 4 the middle estimate is 2.9-fold (0.46 log units) above the measured one; the measured number lies below the stated range.
By their numbers in this assay, from the lowest: compound 4; then compound 3; then compounds 2 and 1 (each within the scatter of the next).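

At this position, between two ring nitrogen atoms, exchanging one six-membered aromatic ring for another still moves the number beyond the scatter in this assay: pyrimidin-2-yl, with its second ring nitrogen, gives a 2.3-fold lower number from compound 3 to compound 4 (0.36 log units; beyond the scatter). Measured against the furans, the same group gives larger steps, a 4.9-fold lower number from compound 2 to compound 4 (0.69 log units; beyond the scatter) and a 5.1-fold lower number from compound 1 to compound 4 (0.71 log units; beyond the scatter). Nothing available here accounts for these changes.

Going by these compounds, whether pyridin-2-yl or pyrimidin-5-yl would match compound 4 remains open. So does whether a methyl group or an amine on the pyrimidin-2-yl ring would keep its lower number.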